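Butylamino to benzylamino on the longer-chain amide

This account rests on a few compounds, and the source may have more. Where it says the series, first, only, none or still open, it means among the compounds named here.

Measured in a functional assay on MCF7 cells (Homo sapiens) for antiproliferative activity, read by MTT assay, with a stated time of 24 h; on this read-out lower numbers stand for stronger inhibition and higher numbers for weaker inhibition:
Compound 1 `CCCCc1oc2ccccc2c1C(=O)c1ccc(OCC(=O)N2CCCC2)cc1`: 42400 nM
Compound 2 `CCCCc1oc2ccccc2c1C(=O)c1ccc(OCC(=O)NCc2ccccc2)cc1`: 19600 nM
Compound 3 `CCCCNC(=O)CCCOc1ccc(C(=O)c2c(CCCC)oc3ccccc23)cc1`: > 50000 nM, a limit and not a number

Compound 3 carries no number, only (the limit of > 50000 nM in this assay, at which 1 of the 3 values shown sits). Two measured steps place it: an at least 2.5-fold higher number from compound 2 to compound 3 (0.40 log units; beyond the scatter), and an at least 1.1-fold higher number from compound 1 to compound 3 (0.07 log units; that floor lies within the scatter).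

Compound 4 `CCCCc1oc2ccccc2c1C(=O)c1ccc(OCCCC(=O)NCc2ccccc2)cc1` differs from compound 3 only at the amide, where butylcarbamoyl becomes benzylcarbamoyl: phenyl in place of propyl on a saturated chain carbon bound to an amide-type nitrogen. Going by the values given here, the nearest precedent for a benzylamino group is a 2.2-fold lower number from compound 1 to compound 2 (0.34 log units; beyond the scatter), although a different amine leaves there and the chain is that of compound 1. The step to compound 3 from compound 2 changes chain and amine together, so it cannot isolate either change. A modest fall in the number is therefore expected in this assay, and its size stays loose since the starting point is a limit. The expected step is an at least 1.7-fold lower number from compound 3 to compound 4 (0.25 log units; that floor lies within the scatter). For compound 4 the estimated value is 28000 nM, with an expected range of 14000 nM to 50000 nM.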

Compound 4, half-maximal inhibitory concentration: 49700 nM
Compound 4: middle estimate off by 1.8-fold (0.25 log units), on the low side; low and high end bracket the measured number.
By their numbers in this assay, from the lowest: compound 2; then compounds 1 and 4 (each within the scatter of the next). At a limit, above all of these: compound 3.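

Compound 4 gives the longer-chain amide series a measured number in this assay: with the benzylamino group, compound 4 gives 49700 nM. The change from butylamino to benzylamino gives a number no higher from compound 3 to compound 4 (the limit leaves the size open). Its size cannot be read, since compound 3 stands at a limit and not at a number: the limit of > 50000 nM in this assay, at which 1 of the 4 values shown sits.

With benzylamino held constant, compound 2 on the shorter chain gives 19600 nM and compound 4 on the longer chain gives 49700 nM, so the lower number of compound 2 does not carry over to the longer chain.

As far as these compounds go, the butylamino amide on the shorter chain and the pyrrolidine amide on the longer chain remain open, and these would separate the effect of the chain from that of the amine. From the compounds shown here alone, a carboxylic acid in place of the amide, or a still longer chain, also remains untested.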